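This account rests on a few compounds, and the source may have more. Where it says the series, first, only, none or still open, it means among the compounds named here.

Compound 1 `COc1cc(/C=C/C(=O)C2=C(/C=C/c3ccc(O)c(OC)c3)NC(=O)NC2c2ccc(C)cc2)ccc1O` is the reference point here. In a functional assay, with a stated time of 20 min, tested at 20 uM (on this read-out higher numbers stand for a stronger effect at the one concentration tested and lower numbers for a weaker effect), compound 1 gives 36.3%, which is the lowest of the three measured numbers. Compound 2 `COc1cc(/C=C/C(=O)C2=C(/C=C/c3ccc(O)c(OC)c3)NC(=O)NC2c2ccccc2O)ccc1O` gives 80.9%, and compound 3 `COc1cc(/C=C/C(=O)C2=C(/C=C/c3ccc(O)c(OC)c3)NC(=O)NC2c2ccc(N(C)C)cc2)ccc1O` gives 82.2%. The step of a number 44.6 percentage points higher from compound 1 to compound 2 (beyond the scatter) and the step of a number 45.9 percentage points higher from compound 1 to compound 3 (beyond the scatter) are both large, whereas the step of a number 1.3 percentage points higher from compound 2 to compound 3 (within the scatter) is not meaningful.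

Compound 4 `COc1cc(/C=C/C(=O)C2=C(/C=C/c3ccc(O)c(OC)c3)NC(=O)NC2c2c(Cl)cccc2Cl)ccc1O` has not yet been measured. It differs from compound 1 in one place: 2,6-dichlorophenyl in place of 4-methylphenyl on a saturated ring carbon

The two measured steps that bear on this change both replaced the 4-methylphenyl group on the same saturated ring carbon and both raised the read-out well beyond the scatter, but neither of the entering groups was 2,6-dichlorophenyl, so the size for compound 4 is uncertain. On that basis compound 4 is expected to give about 62%, with a likely range from 30% to 88%. The expected step is a number 25.7 percentage points higher from compound 1 to compound 4 (beyond the scatter).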

Compound 4, a percentage reported as activity, at one concentration (the size of the read-out at that concentration, not a potency): 33%
For compound 4 the middle estimate is 29 percentage points above the measured one, within the range that was stated.
By their numbers in this assay, from the lowest: compounds 4 and 1 (each within the scatter of the next); then compounds 2 and 3 (each within the scatter of the next).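

In this assay, 2,6-dichlorophenyl in place of 4-methylphenyl on the saturated ring carbon gives a number 3.3 percentage points lower from compound 1 to compound 4 (within the scatter) and so brings no gain, which shows that replacing 4-methylphenyl at this position does not by itself lift the read-out. The two earlier gains therefore depend on which group enters, as a number 49.2 percentage points lower from compound 3 to compound 4 (beyond the scatter) and a number 47.9 percentage points lower from compound 2 to compound 4 (beyond the scatter) make plain for the same position. No measurement available here explains why these groups part so widely. The compounds shown leave open whether a phenyl ring carrying a single chlorine would stay as low as compound 4 or whether both chlorines are needed for that result. They also leave open how a phenyl ring bearing a primary amine or a carboxylic acid would behave at this carbon.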